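Replacing an Isopropyl Group by a Longer Nitrile Chain

A few compounds are considered here, and "the series" means these few. Any claim that something is new, unique, unknown or untested is made for them only; others in the source may bear on it.

Compound 1 `CC(C)n1nc(C(=O)N[C@H]2COc3ccccc3N(C)C2=S)nc1Cc1ccccc1` is the starting point. Going by the values given here, in a functional assay on HT-29 cells (Homo sapiens) for inhibition, read by luminescence and CellTiter-Glo, with a stated time of 24 h (on this read-out higher numbers stand for an effect only at larger amounts of compound and lower numbers for an effect already at smaller amounts), compound 1 gives 360 nM, the lowest of the three numbers measured so far. Two neighbours share its core but carry a different group on the same aromatic nitrogen. Compound 2 `CN1C(=S)[C@@H](NC(=O)c2nc(Cc3ccccc3)n(CCCF)n2)COc2ccccc21` carries a 3-fluoropropyl group there and in this assay gives 4760 nM; compound 3 `CN1C(=S)[C@@H](NC(=O)c2nc(Cc3ccccc3)n(CCC(F)(F)F)n2)COc2ccccc21` carries a 3,3,3-trifluoropropyl group and gives 1550 nM. The measured steps are a 13-fold higher number from compound 1 to compound 2 (1.12 log units; beyond the scatter) and a 4.3-fold higher number from compound 1 to compound 3 (0.63 log units; beyond the scatter); between the two chains, a 3.1-fold lower number from compound 2 to compound 3 (0.49 log units; beyond the scatter).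

Compound 4 `CN1C(=S)[C@@H](NC(=O)c2nc(Cc3ccccc3)n(CCCCC#N)n2)COc2ccccc21` has not yet been measured. It differs from compound 1 as follows: 4-cyanobutyl in place of isopropyl on an aromatic nitrogen. Both measured steps that swap the isopropyl group for a chain on that aromatic nitrogen bear on this change, and both raised the number beyond the scatter, one by a large amount and one by a modest amount. Among the compounds with values here, the 4-cyanobutyl chain is longer than either measured chain and ends in a nitrile, for which no measured step exists, so the expectation rests on the direction shared by compound 2 and compound 3. The expected step is an 8.3-fold higher number from compound 1 to compound 4 (0.92 log units; beyond the scatter), meaning a higher number in this assay. The estimate for compound 4 is 3000 nM, with a range from 1000 nM to 10000 nM.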

Compound 4, half-maximal effective concentration: 2680 nM
The estimate for compound 4 lay 1.1-fold (0.05 log units) above the measured number; the measured number falls inside the stated range.
By their numbers in this assay, from the lowest: compound 1; then compounds 3, 4 and 2 (each within the scatter of the next, the first and the last beyond it).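

In this assay, the 4-cyanobutyl chain, the first chain here to end in a nitrile, also gives a number beyond the scatter of the isopropyl compound, with a 7.4-fold higher number from compound 1 to compound 4 (0.87 log units; beyond the scatter), so all three chains shown on this aromatic nitrogen move the same way from isopropyl. The nitrile chain does not stand apart from the two fluorinated chains, since a 1.7-fold higher number from compound 3 to compound 4 (0.24 log units; within the scatter) and a 1.8-fold lower number from compound 2 to compound 4 (0.25 log units; within the scatter) both stay within the scatter, even though compound 2 and compound 3 are separated by more than the scatter. Nothing available gives a reason why the isopropyl group of compound 1 goes with the lowest number of these four compounds.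

The compounds shown leave open whether a plain propyl chain, or another branched group such as cyclopropyl or tert-butyl, would give a number close to that of compound 1 or close to those of the longer chains. Also open, going by these compounds, is how the number would respond to a shorter nitrile chain such as 2-cyanoethyl, or to a chain ending in an amine or a carboxylic acid.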